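The source may hold more compounds than are shown below. What is called first, only, known or untested is meant among the compounds shown, and "the series" means these compounds.

Compound 1 `Cc1ccc2nc(Cn3c(=O)n(C4CC4)c4ccncc43)c(CCCCO)n2c1` reaches only a limit in an ADME assay on HEp-2 cells (Homo sapiens) for cytotoxicity, read by CCK-8 assay, with a stated time of 6 days (on this read-out lower numbers stand for higher toxicity in this test and higher numbers for lower toxicity in this test), and the reported value for compound 1 is > 100000 nM. Compound 2 `CCc1ccn2c(CCCCO)c(Cn3c(=O)n(C4CC4)c4ccncc43)nc2c1` likewise ends at a limit in this assay, where compound 2 is reported as > 100000 nM. Compound 3 `N#Cc1c(Cn2c(=O)n(C3CC3)c3ccncc32)nc2cc(Cl)ccn12` is the only one of the three with a number: in this assay compound 3 gives 22500 nM, whereas the other two rest at the limit of > 100000 nM in this assay, at which 2 of the 3 values shown sit. Compound 4 `CS(=O)(=O)CCc1c(Cn2c(=O)n(C3CC3)c3ccncc32)nc2cc(Cl)ccn12` differs from compound 3 in one place, (2-(methylsulfonyl)ethyl in place of cyano on an aromatic carbon). Among the measured compounds shown here, no step between two measured compounds is available here, so the expectation rests on the change alone. The step is expected to be a 2.0-fold higher number from compound 3 to compound 4 (0.30 log units; within the scatter), in the direction of the limit. Compound 4 is therefore estimated at about 45000 nM, within a range from 15000 nM to 100000 nM.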

Compound 4, half-maximal cytotoxic concentration: > 100000 nM
Compound 4: a limit, no number (the forecaster's own chance of this, stated with the estimate: 45%); middle value at least 2.2-fold (0.34 log units) away from the limit.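

At this aromatic carbon of the five-membered ring, 2-(methylsulfonyl)ethyl in place of cyano gives an at least 4.4-fold higher number from compound 3 to compound 4 (0.64 log units; beyond the scatter) in this assay, so a change in this one place moves the read-out beyond the scatter. Compound 4 gives > 100000 nM, which is a limit and not a number, so the step has a lower bound only: the limit of > 100000 nM in this assay, at which 3 of the 4 values shown sit.

Going by these compounds, how far the true value of compound 4 lies past that limit remains open. Also open, on these data alone, is where an amine, a carboxylic acid or a shorter sulfone chain on this carbon would fall.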